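Replacing the Acid Tail with an Amine Tail

A few compounds are considered here, and "the series" means these few. Any claim that something is new, unique, unknown or untested is made for them only; others in the source may bear on it.

In a functional assay on the whole organism with Mus musculus as the target (a lower number here means that less compound is needed, a higher number that more compound is needed for the effect), three compounds have been measured so far:

compound 1, `Cc1c(C)c2c(c(C)c1N)CC(C)(CSc1ccc(F)cc1)O2`: 17.9 mg/kg
compound 2, `Cc1c(C)c2c(c(C)c1N)CC(C)(CSc1ccc(O)cc1)O2`: a limit of the assay, > 50 mg/kg, not a number
compound 3, `Cc1c(C)c2c(c(C)c1N)CC(C)(CSCCC(=O)O)O2`: 43 mg/kg

Compound 3 carries the highest of the two numbers that were obtained. Its nearest neighbour is compound 1, and the gap between them is a 2.4-fold higher number from compound 1 to compound 3 (0.38 log units; beyond the scatter), produced by putting 2-carboxyethyl in place of 4-fluorophenyl on the sulfur. The comparison with compound 2 is different in kind, since compound 2 sits at the limit (the limit of > 50 mg/kg in this assay, at which 1 of the 3 values shown sits); the step of an at least 1.1-fold lower number from compound 2 to compound 3 (0.06 log units; that floor lies within the scatter) therefore has only a floor, and that floor lies within the scatter.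

Compound 4, `Cc1c(C)c2c(c(C)c1N)CC(C)(CCN(C)C)O2`, is the next compound to be measured. It differs from compound 3 by (dimethylamino)methyl in place of (2-carboxyethyl)sulfanyl on a saturated chain carbon bound to a saturated ring carbon.

Going by the values given here, no measured step makes this kind of exchange, so the expectation rests on the two steps that alter the group on the sulfur: one was modest and one could not be resolved beyond the scatter. A modest move toward a lower number is therefore expected, namely a 2.2-fold lower number from compound 3 to compound 4 (0.33 log units; beyond the scatter). Compound 4 is estimated at 20 mg/kg, with a range from 8 mg/kg to 50 mg/kg.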

Compound 4, dose for 50% inhibition: 19 mg/kg
For compound 4 the middle estimate is 1.1-fold (0.02 log units) above the measured one, and the stated range covers the measured number.
By their numbers in this assay, from the lowest: compounds 1 and 4 (each within the scatter of the next); then compound 3. At a limit, above all of these: compound 2.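

Putting (dimethylamino)methyl in place of (2-carboxyethyl)sulfanyl on this saturated chain carbon bound to a saturated ring carbon gives a 2.3-fold lower number from compound 3 to compound 4 (0.35 log units; beyond the scatter) in this assay, so less compound is needed for the effect. The earlier compounds shown here all hold a sulfur in this tail, whereas compound 4 has none, which shows that a sulfur is not required here for a number in this range. An aromatic ring in the tail is not required either: compound 1, with 4-fluorophenyl on the sulfur, gives 17.9 mg/kg, and compound 4, with no ring in the part that changed, gives 19 mg/kg, two numbers within the scatter of each other.

This single exchange removes the sulfur and the carboxylic acid and brings in the amine all at once, so the compounds shown cannot say which of these changes carries the step. They also leave open how a sulfur-free chain ending in a carboxylic acid, a plain alkyl chain, a longer chain ending in dimethylamino, or a piperidine in place of the dimethylamino group would read in this assay.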